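This account rests on a few compounds, and the source may have more. Where it says the series, first, only, none or still open, it means among the compounds named here.

In an ADME assay on THP-1 cells (Homo sapiens) for cytotoxicity, read by resazurin assay, with a stated time of 72 h (a higher number here means that more compound is tolerated, a lower number that less compound is tolerated), compound 1 (`C#CCOc1ccc(C(=O)/C=C/c2cccnc2)c(O)c1`) gives 25000 nM and compound 2 (`C#CCOc1ccc(C(=O)/C=C/c2cccnc2)c(OC)c1`) gives 16000 nM in the same read-out. Compound 3 (`C#CCOc1ccc(C(=O)/C=C/c2ccncc2)c(OCC#C)c1`) gives 11000 nM here, within the scatter of compound 2 and beyond the scatter below compound 1. Compound 4 (`C#CCOc1ccc(C(=O)/C=C/c2cccnc2)c(OCC#C)c1`) carries pyridin-3-yl in place of pyridin-4-yl on a double-bonded chain carbon bound to a double-bonded chain carbon. Among the compounds with values here, no measured pair tests this change. Within the data shown here, the only measured step (a 1.6-fold lower number from compound 1 to compound 2 (0.19 log units; within the scatter)) lies elsewhere, methyl in place of hydrogen on an oxygen on an aromatic ring, and stays within the scatter. In this assay the expected step (a 1.2-fold higher number from compound 3 to compound 4 (0.07 log units; within the scatter)) is therefore none beyond the scatter. Compound 4 is estimated at 13000 nM with an expected range from 7000 nM to 24000 nM for four of five measurements.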

Compound 4, half-maximal cytotoxic concentration: 15000 nM
Beside the measured number, compound 4's estimate is 1.2-fold (0.06 log units) below it; measured number inside the range.
By their numbers in this assay, from the lowest: compounds 3, 4, 2 and 1 (each within the scatter of the next, the first and the last beyond it).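

In this assay, within the data shown here, pyridin-3-yl in place of pyridin-4-yl on a double-bonded chain carbon bound to a double-bonded chain carbon gives the first measured reading of this change (a 1.4-fold higher number from compound 3 to compound 4 (0.13 log units; within the scatter)), and the swap stays within the scatter. On the oxygen on an aromatic ring, propargyl in place of hydrogen (a 1.7-fold lower number from compound 1 to compound 4 (0.22 log units; within the scatter)) and ethynyl in place of hydrogen on the saturated chain carbon (a 1.1-fold lower number from compound 2 to compound 4 (0.03 log units; within the scatter)) also stay within the scatter. No measurement offered here accounts for these steps.

Open, as far as these compounds go, is how pyridin-2-yl would read at this place. Also open, from the compounds shown here alone, is whether a longer chain or an amine on that oxygen would move the number beyond the scatter.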